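A Tolyl Sulfonyl Variant in a Flat Series

The compounds below may be only part of what the source reports. "The series", "measured", "known", "first", "only" and "open" are said of these compounds alone.

Of the compounds shown here, three sharing one core have been measured in a functional assay on HepG2 cells (Homo sapiens) for antiproliferative activity, read by MTT assay, with a stated time of 48 h; a higher number here means a weaker inhibitor, a lower number a stronger inhibitor. Compound 1 `O=C(/C=C/c1cn(S(=O)(=O)c2ccccc2[N+](=O)[O-])c2ccccc12)c1ccncc1` gives 31700 nM. Compound 2 `O=C(/C=C/c1c[nH]c2ccccc12)c1ccncc1`, which carries no sulfonyl group at all, gives 49300 nM. Compound 3 `O=C(/C=C/c1cn(S(=O)(=O)c2cccc([N+](=O)[O-])c2)c2ccccc12)c1ccncc1` gives 42600 nM. Compound 1 shows the lowest of the three numbers, but its separation from compound 3 is a 1.3-fold higher number from compound 1 to compound 3 (0.13 log units; within the scatter), within the scatter, and its separation from compound 2 is likewise within the scatter, so no order among the three can be claimed.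

Compound 4 `Cc1ccc(S(=O)(=O)n2cc(/C=C/C(=O)c3ccncc3)c3ccccc32)cc1` differs from compound 1 in one place: 4-methylphenyl in place of 2-nitrophenyl on a sulfonyl sulfur. Among the compounds with values here, the only measured step that bears on this, the exchange of one nitrophenyl for another on the same sulfonyl sulfur, was a 1.3-fold higher number from compound 1 to compound 3 (0.13 log units; within the scatter) and stayed inside the scatter; even the absence of the whole sulfonyl group, as compound 2 set against compound 1 shows, did not move the read-out beyond it. These numbers give no sign that a change at this sulfur shifts the result, so for compound 4 the step is expected to be a 1.1-fold higher number from compound 1 to compound 4 (0.04 log units; within the scatter), none beyond the scatter. The estimate for compound 4 in this assay is therefore 35000 nM, with a range from 15000 nM to 80000 nM.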

Compound 4, half-maximal inhibitory concentration: 44800 nM
Compound 4: middle estimate off by 1.3-fold (0.11 log units), on the low side, within the range that was stated.
By their numbers in this assay, from the lowest: compounds 1, 3, 4 and 2 (each within the scatter of the next).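

In this assay, putting 4-methylphenyl on a sulfonyl sulfur whose other neighbour is the aromatic nitrogen gives a 1.4-fold higher number from compound 1 to compound 4 (0.15 log units; within the scatter) when it replaces 2-nitrophenyl and a 1.1-fold higher number from compound 3 to compound 4 (0.02 log units; within the scatter) when it replaces 3-nitrophenyl. The earlier step only moved the nitro group from one nitrophenyl to the other, whereas this change removes it altogether, along with the hydrogen-bond acceptors counted on the group that leaves, and the read-out still does not separate the compounds. At this position, then, the three aryl groups shown cannot be told apart in this read-out, though no measurement is available here that could account for this.

Going by these compounds, all three groups on the sulfur are six-membered aromatic rings of carbon only, so it remains open whether a different kind of group there, such as an amine, a carboxylic acid or a longer alkyl chain, would give a step beyond the scatter. Also open is whether any change elsewhere on the shared core would move the read-out, as every compound shown keeps the rest of that core unchanged.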